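This account rests on a few compounds, and the source may have more. Where it says the series, first, only, none or still open, it means among the compounds named here.

Measured compounds and their values:
- compound 1, `N[C@H]1CC[C@@H](Oc2ccc([C@H]3CC[C@]4(CC3)OOC3(O4)C4CC5CC(C4)CC3C5)cc2)CC1`: < 7 mL.min-1.g-1
- compound 2, `CS(=O)(=O)N1CCN(CCCOc2ccc([C@H]3CC[C@]4(CC3)OOC3(O4)C4CC5CC(C4)CC3C5)cc2)CC1`: 68 mL.min-1.g-1
- compound 3, `O[C@H]1CC[C@H](NCCCOc2ccc([C@H]3CC[C@]4(CC3)OOC3(O4)C4CC5CC(C4)CC3C5)cc2)CC1`: < 7 mL.min-1.g-1

In an ADME assay on microsomes from liver (Homo sapiens) for metabolic stability, read by LC-MS, tested at 1 uM (on this read-out higher numbers stand for fast clearance and lower numbers for slow clearance), compound 3 gives < 7 mL.min-1.g-1, which is a limit of the assay and not a number. Compound 3 thus stands at the limit of < 7 mL.min-1.g-1 in this assay, at which 2 of the 3 values shown sit. For the measured compounds named here, the one step that reaches compound 3 with a readable size is an at least 9.7-fold lower number from compound 2 to compound 3 (0.98 log units; beyond the scatter); the other, a step that the two limits leave unreadable from compound 1 to compound 3, cannot be sized because both ends are limits. Compound 4, `NCCS(=O)(=O)CCOc1ccc([C@H]2CC[C@]3(CC2)OOC2(O3)C3CC4CC(C3)CC2C4)cc1`, has not yet been measured. It differs from compound 3 by (2-aminoethyl)sulfonyl in place of ((4-hydroxycyclohexyl)amino)methyl on a saturated chain carbon, two bonds along the chain from an oxygen on an aromatic ring. Of the measured steps, the change from compound 2 to compound 3 bears most on it, since it also swaps the end group of the chain, but here a sulfonyl enters rather than leaves, so its direction is not simply reversed. Compound 1, which also carries a primary amine, sits at the limit. Compound 4 is therefore expected to show an at least 1.7-fold higher number from compound 3 to compound 4 (0.23 log units; that floor lies within the scatter), towards faster clearance. Compound 4 is estimated at 12 mL.min-1.g-1, with a range from 5 mL.min-1.g-1 to 35 mL.min-1.g-1.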

Compound 4, intrinsic clearance in microsomes: 9 mL.min-1.g-1
The estimate for compound 4 lay 1.3-fold (0.12 log units) above the measured number; the measured number falls inside the stated range.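

With a sulfonyl in the chain, a low reading is still possible in this assay: (2-aminoethyl)sulfonyl in place of (4-(methylsulfonyl)piperazin-1-yl)methyl gives a 7.6-fold lower number from compound 2 to compound 4 (0.88 log units; beyond the scatter), so a sulfonyl alone does not go with the high number of compound 2. The steps to the two compounds without a readable number are an at least 1.2-fold higher number from compound 3 to compound 4 (0.10 log units; that floor lies within the scatter) and an at least 1.2-fold higher number from compound 1 to compound 4 (0.10 log units; that floor lies within the scatter), and neither floor sets compound 4 apart from them. Compound 1 and compound 3 each give only a limit of the assay: the limit of < 7 mL.min-1.g-1 in this assay, at which 2 of the 4 values shown sit.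

The compounds shown do not separate the part played by the sulfonyl from that of the end amine, since each step changes a whole group. A carboxylic acid in place of that amine, or a longer chain between it and the sulfonyl, would bear on this question.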